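A chain swapped for a ring at the assay limit

The source may report more compounds than this note shows. Statements on the series, on what has been measured and on what is new or still open speak of the compounds shown alone.

Measured so far in an ADME assay on HEK293 cells (Homo sapiens) for cytotoxicity, read by ATP content, with a stated time of 6 h; on this read-out lower numbers stand for higher toxicity in this test and higher numbers for lower toxicity in this test (both entries are limits, not numbers):
- Compound 1 `CCCCNc1nc(N)nc2ccn(Cc3ccccn3)c12` gives > 24000 nM (a limit)
- Compound 2 `CCC(O)CNc1nc(N)nc2ccn(Cc3ccccn3)c12` gives > 24000 nM (a limit)

Compound 2 gives no exact number, only the limit > 24000 nM. Both measured compounds stand at the same place: the limit of > 24000 nM in this assay, at which 2 of the 2 values shown sit. Among the measured compounds shown here, the only measured step, a step that the two limits leave unreadable from compound 1 to compound 2, has no readable size, so it offers no size to carry forward.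

Compound 3 `Cc1ccc(CNc2nc(N)nc3ccn(Cc4ccccn4)c23)nc1` differs from compound 2 by having 5-methylpyridin-2-yl in place of 1-hydroxypropyl on a saturated chain carbon bound to a nitrogen on an aromatic ring. With no measured size to draw on, no change beyond the usual scatter is expected in this assay, and no direction can be favoured. The expected step is a step that the limit leaves unreadable from compound 2 to compound 3. The estimate for compound 3 is 30000 nM, with an expected range from 12000 nM to 70000 nM.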

Compound 3, half-maximal cytotoxic concentration: > 24000 nM
Compound 3 was reported as a limit (the forecaster's own chance of this, stated with the estimate: 75%); the middle value lies beyond the limit too.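

Compound 3 also comes back only as a limit, so neither its step from compound 2 nor its step from compound 1 can be read: the limit of > 24000 nM in this assay, at which 3 of the 3 values shown sit.

Still open, as far as these compounds go, is whether compound 1, compound 2 and compound 3 truly differ in this assay and what exact value each would give.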